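The compounds below may be only part of what the source reports. "The series", "measured", "known", "first", "only" and "open" are said of these compounds alone.

Compound 1 `O=C1O/C(=C\Cn2cc(-c3cc(F)cc(F)c3)nn2)C(OCc2ccccc2)=C1OCc1ccccc1`: "not active" (no number reported)
Compound 2 `CCCCCc1ccc(-c2cn(C[C@H](O)[C@H]3OC(=O)C(OCc4ccccc4)=C3OCc3ccccc3)nn2)cc1`: 9890 nM
Compound 3 `O=C1O/C(=C\Cn2cc(-c3cc(C(F)(F)F)cc(C(F)(F)F)c3)nn2)C(OCc2ccccc2)=C1OCc1ccccc1`: > 100000 nM

These results come from a functional assay on CFPAC-1 cells (Homo sapiens) for antiproliferative activity, read by MTT assay, with a stated time of 72 h; on this read-out lower numbers stand for stronger inhibition and higher numbers for weaker inhibition. Within the data shown here, compound 2 holds the only actual number of the three, at 9890 nM. Compound 3 gives > 100000 nM, which is a limit of the assay and not a number. Compound 1 is recorded as "not active" (no number reported), with no number at all.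

The next compound is compound 4 `O=C1O[C@H]([C@@H](O)Cn2cc(C3CC3)nn2)C(OCc2ccccc2)=C1OCc1ccccc1`. It departs from compound 2 at a single place: cyclopropyl in place of 4-pentylphenyl on an aromatic carbon. Put simply, this is cyclopropyl in place of 4-pentylphenyl on an aromatic carbon, so a much smaller group takes over that spot.

Among the measured compounds shown here, no measured pair shows this change in this assay, which makes any forecast tentative. For the measured compounds named here, compound 2, at 9890 nM, is the only compound here with a numerical result, and the other two offer no number to suggest that activity would improve. The expected 3.0-fold higher number from compound 2 to compound 4 (0.48 log units; beyond the scatter) is therefore a moderate weakening, beyond the usual scatter. For compound 4 the estimated value is 30000 nM, with an expected range of 8000 nM to 100000 nM.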

Compound 4, half-maximal inhibitory concentration: 47700 nM
The estimate for compound 4 lay 1.6-fold (0.20 log units) below the measured number; the range from low to high includes it.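

Replacing 4-pentylphenyl with cyclopropyl on this aromatic carbon of the five-membered aromatic ring with 3 nitrogen gives a 4.8-fold higher number from compound 2 to compound 4 (0.68 log units; beyond the scatter) in this assay, the first measured sign that activity responds to the group at this position. The step is modest, so the large 4-pentylphenyl, with its 11 heavy atoms, is not needed for compound 4 to give a measurable result, even with only the 3 heavy atoms of cyclopropyl in its place. Compound 4 also keeps an actual number instead of stopping at the limit of the assay: the limit of > 100000 nM in this assay, at which 1 of the 4 values shown sits.

Among these compounds, with only two groups compared here, the step cannot be assigned to the loss of the pentyl chain, the loss of the aromatic ring or the drop in size. An unsubstituted phenyl or a cyclohexyl on the same carbon would help to separate these three changes.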